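The compounds below may be only part of what the source reports. "The series", "measured", "known", "first", "only" and "open" are said of these compounds alone.

Compound 1 `CC1(C)CC(=O)C=C(Nc2ccc(Cl)cc2Cl)C1` reaches only the limit > 100 ug/mL in a functional assay on cells (blood, Homo sapiens) for inhibition, read by chemiluminescence, with a stated time of 30 min; a higher number here means a weaker inhibitor, a lower number a stronger inhibitor.
Compound 2 `CCCCCCCCCCCSC(=S)C1=C(Nc2ccc(Cl)cc2Cl)CC(C)(C)CC1=O` also gives only the limit > 100 ug/mL in this assay.
Compound 3 `CC1(C)CC(=O)C(C(=S)SCc2ccccc2)=C(Nc2ccc(Cl)cc2Cl)C1` likewise gives only the limit > 100 ug/mL in this assay.

Compound 3 therefore stands at a limit, not at a number, and every value shown sits at the same point: the limit of > 100 ug/mL in this assay, at which 3 of the 3 values shown sit. Going by the values given here, the one step between measured compounds, a step that the two limits leave unreadable from compound 2 to compound 3, cannot be read for the same reason. Compound 4 `CC1(C)CC(=O)C(C(=S)SCCO)=C(Nc2ccc(Cl)cc2Cl)C1` differs from compound 3 by hydroxymethyl in place of phenyl on a saturated chain carbon bound to a sulfur. Among the compounds with values here, no measured step bears readably on this change, so no direction can be drawn from it. Compound 4 is expected to stay at the limit as well, and its estimate is 150 ug/mL with a range of 50 ug/mL to 500 ug/mL. The step that the limit leaves unreadable from compound 3 to compound 4 is thus expected to remain unreadable in this assay.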

Compound 4, half-maximal inhibitory concentration: > 100 ug/mL
Compound 4 ended at the assay's limit; the forecaster's own chance of this, stated with the estimate: 85%; the middle value lies beyond the limit too.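

Compound 4 also gives only a limit, > 100 ug/mL, in this assay, so its steps from compound 1, compound 2 and compound 3 cannot be read. The compounds shown leave open how strongly any of them inhibits, since every value is a limit: the limit of > 100 ug/mL in this assay, at which 4 of the 4 values shown sit.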